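A few compounds are considered here, and "the series" means these few. Any claim that something is new, unique, unknown or untested is made for them only; others in the source may bear on it.

In an assay on isolated protein for binding affinity to Bile acid receptor (Homo sapiens), read by FRET (on this read-out lower numbers stand for an effect already at smaller amounts and higher numbers for an effect only at larger amounts of compound), two compounds have been measured so far. Compound 1, `CC(C)c1onc(-c2c(Cl)cccc2Cl)c1COc1ccc2c(c1)CN(c1cccc(C(=O)O)c1)C2=O`, gives 670 nM. Compound 2, `CC(C)c1onc(-c2c(Cl)cccc2Cl)c1COc1ccc2c(ccn2Cc2cccc(C(=O)O)c2)c1`, gives 320 nM. Compound 2 thus stands at the lower of the two numbers, and the gap between it and compound 1 lies beyond the usual scatter of repeated measurements, so compound 2 is the one that acts at the smaller amount. Since the two differ in more than one place, no single structural step can be read from that pair.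

The next compound, compound 3, `CC(C)c1onc(-c2c(Cl)cccc2Cl)c1COc1ccc2c(ccn2Cc2ccc(C(=O)O)cc2)c1`, has not yet been measured. It differs from compound 2 in a single place: 4-carboxyphenyl in place of 3-carboxyphenyl on a saturated chain carbon bound to an aromatic nitrogen. The two compounds share the same atoms, joined differently, so this is a change of arrangement rather than of size.

Among the compounds with values here, no measured pair shows what shifting the acid around that ring does here, so the expectation for compound 3 rests on compound 2 alone. Compound 3 is expected to give about 550 nM, somewhere between 150 nM and 2000 nM. That expected step, a 1.7-fold higher number from compound 2 to compound 3 (0.24 log units; within the scatter), is a small weakening that may well stay within the scatter.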

Compound 3, half-maximal effective concentration: 160 nM
Beside the measured number, compound 3's estimate is 3.4-fold (0.54 log units) above it; measured number inside the range.
By their numbers in this assay, from the lowest: compounds 3 and 2 (each within the scatter of the next); then compound 1.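

Within the data shown here, this is the first pair that differs in only one place, so it gives the first direct reading at this position: in this assay, 4-carboxyphenyl in place of 3-carboxyphenyl on a saturated chain carbon bound to an aromatic nitrogen gives a 2.0-fold lower number from compound 2 to compound 3 (0.30 log units; within the scatter). The two compounds hold the same atoms, joined differently, and this change of arrangement keeps the numbers so close that neither compound can be ranked above the other. Nothing measured alongside these compounds bears on why the two arrangements read alike.

The pair shows only that these two arrangements read alike, so it says nothing about whether the carboxylic acid is needed at all, which a primary amide or a tetrazole in its place would test. Also open, on these data alone, is how the number responds to a longer chain in place of the single saturated carbon that joins the aromatic nitrogen to the ring carrying the acid.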